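This account rests on a few compounds, and the source may have more. Where it says the series, first, only, none or still open, it means among the compounds named here.

In a functional assay on HCT-116 cells (Homo sapiens) for inhibition, read by colorimetric assay, with a stated time of 3 days (a higher number here means a weaker inhibitor, a lower number a stronger inhibitor), three compounds sharing one core have been measured so far. Compound 1 `O=C(CCCCCCNC(=O)C(O)(O)C(F)(F)F)Nc1nc2ccccc2o1` gives 3450 nM, compound 2 `O=C(CCCCCCNC(=O)C(O)(O)C(F)(F)F)Nc1ccc(Br)cc1` gives 3130 nM, and compound 3 `O=C(CCCCCCNC(=O)C(O)(O)C(F)(F)F)Nc1nc2ccccc2s1` gives 2370 nM. Compound 3 thus lies within the scatter of both others, and no order can be read among the three.

The unmeasured compound 4 `O=C(CCCCCCNC(=O)C(O)(O)C(F)(F)F)Nc1cccc(Br)c1` differs from compound 3 by 3-bromophenyl in place of 1,3-benzothiazol-2-yl on an amide-type nitrogen. All three measured steps concern this same nitrogen. The closest is a 1.3-fold lower number from compound 2 to compound 3 (0.12 log units; within the scatter), since compound 2 also carries a bromophenyl group there, so this step runs in the opposite sense to the one in question. The other two are a 1.5-fold lower number from compound 1 to compound 3 (0.16 log units; within the scatter) and a 1.1-fold lower number from compound 1 to compound 2 (0.04 log units; within the scatter). For the measured compounds named here, each of these exchanges stayed within the scatter, although no measured pair shows what the place of the bromine on the ring does.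

No step beyond the scatter is therefore expected in this assay, in either direction. The expected change is a 1.3-fold higher number from compound 3 to compound 4 (0.10 log units; within the scatter). For compound 4 the estimated value is 3000 nM, with an expected range of 1500 nM to 6000 nM.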

Compound 4, half-maximal inhibitory concentration: 3060 nM
Beside the measured number, compound 4's estimate is 1.0-fold (0.01 log units) below it; the measured number falls inside the stated range.
By their numbers in this assay, from the lowest: compounds 3, 4, 2 and 1 (each within the scatter of the next).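

In this assay, for the compounds shown here, the step of a 1.0-fold lower number from compound 2 to compound 4 (0.01 log units; within the scatter) is the first measured pair that shows what the place of the bromine on the ring does, and at this amide-type nitrogen 3-bromophenyl and 4-bromophenyl cannot be told apart. The exchanges of 3-bromophenyl for the two groups with a five-membered aromatic ring, a 1.3-fold higher number from compound 3 to compound 4 (0.11 log units; within the scatter) and a 1.1-fold lower number from compound 1 to compound 4 (0.05 log units; within the scatter), also stay within the scatter, so with the earlier steps, every measured exchange among these four groups on this nitrogen gives no readable difference, and there are no exceptions among the compounds shown. Nothing at hand explains why these exchanges leave the number so little changed.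

The compounds shown leave open whether an amine or a carboxylic acid on the phenyl ring, or a saturated ring in place of the aromatic groups on this nitrogen, would move the number beyond the scatter. They also leave open what a longer chain in the shared core would do, since all four compounds carry the same chain.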